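The source may report more compounds than this note shows. Statements on the series, on what has been measured and on what is new or still open speak of the compounds shown alone.

Of the compounds shown here, two sharing one core have been tested in an ADME assay on HEK-293T cells (Homo sapiens) for cytotoxicity, read by MTT assay, with a stated time of 72 h; on this read-out higher numbers stand for weaker inhibition and lower numbers for stronger inhibition. Compound 1 `O=C(Cn1c(-c2ccccc2)cc(-c2ccccc2)c1-c1ccco1)Nc1ccccn1` gives only a limit of the assay, < 50000 nM. Compound 2 `CCc1nnc(NC(=O)Cn2c(-c3ccccc3)cc(-c3ccccc3)c2-c2ccccc2)s1` likewise gives only a limit, < 50000 nM, so its standing rests on the limit of < 50000 nM in this assay, at which 2 of the 2 values shown sit, and not on a number. Compound 3 `O=C(Cn1c(-c2ccccc2)cc(-c2ccccc2)c1-c1ccccc1)Nc1ccccn1` differs from compound 2 by pyridin-2-yl in place of 5-ethyl-1,3,4-thiadiazol-2-yl on an amide-type nitrogen. Among the compounds with values here, with no step between measured compounds to draw on, the expected change a step that the limit leaves unreadable from compound 2 to compound 3 in this assay is none beyond the scatter. Compound 3 is therefore estimated at 20000 nM, between 5000 nM and 50000 nM.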

Compound 3, half-maximal inhibitory concentration: < 50000 nM
Compound 3 gave a limit, no number; the forecaster's own chance of this, stated with the estimate: 60%; the middle value does not contradict the limit.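

Within the data shown here, compound 3 gives only a limit and no number, as do compound 1 and compound 2, so no step among them can be read: the limit of < 50000 nM in this assay, at which 3 of the 3 values shown sit. In this assay the compounds shown leave open how strongly each one inhibits, and whether either change of group moves the read-out at all.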